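The compounds below may be only part of what the source reports. "The series", "measured", "known", "first", "only" and "open" are said of these compounds alone.

Working notes on the series

Three compounds of this series have a number in a functional assay on NUGC-3 cells (Homo sapiens) for cytotoxicity, read by sulforhodamine B assay, with a stated time of 72 h; on this read-out lower numbers stand for stronger inhibition of growth and higher numbers for weaker inhibition of growth. Compound 3 `O=C(Nc1cc(C(F)(F)F)cc(C(F)(F)F)c1)C1CCc2ccccc2N1C(=O)c1ccc(Cl)cc1` stands lowest there: in this assay compound 3 gives 1660 nM. The nearest is compound 1 `CCCCCCCCC(=O)N1c2ccccc2CCC1C(=O)Nc1ccccc1C(F)(F)F`, which gives 6180 nM in this assay, and the furthest is compound 2 `COc1ccc(NC(=O)C2CCc3ccccc3N2)cc1`, which in this assay gives 51900 nM; both gaps from compound 3 lie beyond the scatter, so compound 3 is the strongest inhibitor of growth among the three. No pair of these three differs in only one place, so nothing is said here of the cause of the gaps between them.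

Compound 4 `O=C(Nc1cc(C(F)(F)F)cc(C(F)(F)F)c1)C1CCc2ccccc2N1C(=O)c1ccccc1Cl` is not yet measured. It differs from compound 3 in one place: 2-chlorophenyl in place of 4-chlorophenyl on a carbonyl carbon. Among the compounds with values here, with no single-point step between measured compounds to lean on, the expectation is a small step in this assay, with at most a slight weakening, probably within the scatter. Compound 4 is expected to give about 2500 nM in this assay, within 800 nM to 8000 nM, a change from compound 3 of a 1.5-fold higher number from compound 3 to compound 4 (0.18 log units; within the scatter).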

Compound 4, concentration for 50% growth inhibition: 1930 nM
Beside the measured number, compound 4's estimate is 1.3-fold (0.11 log units) above it; low and high end bracket the measured number.
By their numbers in this assay, from the lowest: compounds 3 and 4 (each within the scatter of the next); then compound 1; then compound 2.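

Within the data shown here, this pair is the first that differs in one place only, and so the first reading of the chlorophenyl group on a carbonyl carbon whose other neighbour is the amide-type nitrogen in a ring. In this assay, 2-chlorophenyl in place of 4-chlorophenyl gives a 1.2-fold higher number from compound 3 to compound 4 (0.07 log units; within the scatter) here, so the two isomers cannot be told apart and both stay at the low end of the series. Nothing measured here bears on why the two groups read alike.

As far as these compounds go, it remains open whether this carbonyl carbon tolerates other groups as well, such as an unsubstituted phenyl, a pyridine ring, a phenyl carrying an amine or a carboxylic acid, or a longer chain. The gaps to compound 1 and compound 2 span more than one place and cannot be read as steps.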